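The source may hold more compounds than are shown below. What is called first, only, known or untested is meant among the compounds shown, and "the series" means these compounds.

Compound 1 `Cc1ccc(N2CCN(C(=O)C3CCN(C(=O)c4ccc(S(C)(=O)=O)c([N+](=O)[O-])c4)CC3)CC2)cc1` carries a 4-methylphenyl group on an amine nitrogen in a ring. In an assay on isolated protein for inhibition of thyroid hormone receptor beta (Homo sapiens), read by fluorescence polarization (a higher number here means a weaker inhibitor, a lower number a stronger inhibitor), compound 1 reaches only the limit of the assay, > 60000 nM. Compound 2 `CN1CCN(C(=O)C2CCN(C(=O)c3ccc(S(C)(=O)=O)c([N+](=O)[O-])c3)CC2)CC1` has methyl in place of 4-methylphenyl on that nitrogen. In this assay compound 2 likewise gives only the limit, > 60000 nM. The step that the two limits leave unreadable from compound 1 to compound 2 therefore cannot be read, since (the limit of > 60000 nM in this assay, at which 2 of the 2 values shown sit). Compound 3 `CS(=O)(=O)c1ccc(C(=O)N2CCC(C(=O)N3CCN(c4ccccc4)CC3)CC2)cc1[N+](=O)[O-]` differs from compound 2 by phenyl in place of methyl on an amine nitrogen in a ring. Among the compounds with values here, the only measured step concerns the same position and is unreadable, so nothing measured points to a change beyond the scatter in either direction. Compound 3 is expected to sit at the limit in this assay as compound 2 does. Compound 3 is therefore estimated at 80000 nM, with a range from 20000 nM to 300000 nM. The step that the limit leaves unreadable from compound 2 to compound 3 is expected to lie within the scatter.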

Compound 3, half-maximal inhibitory concentration: > 60000 nM
Compound 3 gave a limit, no number (the forecaster's own chance of this, stated with the estimate: 85%); the middle value is on the limit's open side.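

In this assay compound 3 also reaches only a limit of the assay, > 60000 nM, so no step among compound 1, compound 2 and compound 3 can be read: the limit of > 60000 nM in this assay, at which 3 of the 3 values shown sit.

These compounds leave open whether any group on that amine nitrogen in a ring would give a readable value.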